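The compounds below may be only part of what the source reports. "The series", "measured", "known", "first", "only" and "open" are said of these compounds alone.

In a functional assay on MCF7 cells (Homo sapiens) for inhibition, read by MTT assay, with a stated time of 72 h (a higher number here means a weaker inhibitor, a lower number a stronger inhibitor), compound 3 `Nc1nc2cc(-c3nn(CCCCCC(=O)NO)c4ncnc(N)c34)ccc2o1` gives 12400 nM. Within the data shown here, compound 1 `CNC(=O)CCCCCCCn1nc(-c2cnc3[nH]ccc3c2)c2c(N)ncnc21`, the one measured compound ending in methylcarbamoyl, gives 7570 nM, and these two values lie within the scatter of each other. Compound 2 `Nc1nc2cc(-c3nn(CCCCCCCCCC(=O)NO)c4ncnc(N)c34)ccc2o1` reads > 50000 nM, which is a limit of the assay and not a number.

Next in line is compound 4 `CNC(=O)CCCCCCCn1nc(-c2ccc3oc(N)nc3c2)c2c(N)ncnc21`, which carries 2-(methylcarbamoyl)ethyl in place of hydroxycarbamoyl on a saturated chain carbon, five bonds along the chain from an aromatic nitrogen. One measured step acts at this same place: an at least 4.0-fold lower number from compound 2 to compound 3 (0.60 log units; beyond the scatter). Read in reverse, that step ties a longer group at this place to a higher number, but it keeps the hydroxycarbamoyl end, which compound 4 gives up. Among the measured compounds shown here, the exchange of end groups has no measured step of its own. For the measured compounds named here, the only guide to it is compound 1 at 7570 nM, which stays in the measurable range. A modest move toward a higher number is therefore expected in this assay, smaller than the measured step, and the expected step is a 2.3-fold higher number from compound 3 to compound 4 (0.35 log units; beyond the scatter). For compound 4 the estimated value is 28000 nM, with an expected range of 9000 nM to 50000 nM.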

Compound 4, half-maximal inhibitory concentration: 7220 nM
Compound 4: middle estimate off by 3.9-fold (0.59 log units), on the high side; measured number outside the range, below it.
By their numbers in this assay, from the lowest: compounds 4, 1 and 3 (each within the scatter of the next). At a limit, above all of these: compound 2.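

In this assay, the end group at this place can now be read on its own, on a saturated chain carbon, five bonds along the chain from an aromatic nitrogen: a 1.7-fold lower number from compound 3 to compound 4 (0.23 log units; within the scatter). This puts 2-(methylcarbamoyl)ethyl and hydroxycarbamoyl on equal terms here, so in this pair the hydroxycarbamoyl end is not needed to hold the number at this level, and the aromatic group on the shared core can also be read with the methylcarbamoyl chain held fixed: a 1.0-fold lower number from compound 1 to compound 4 (0.02 log units; within the scatter). Among these compounds, the only new step beyond the scatter is an at least 6.9-fold lower number from compound 2 to compound 4 (0.84 log units; beyond the scatter), and it starts from compound 2, whose reading is a limit of the assay and not a number: the limit of > 50000 nM in this assay, at which 1 of the 4 values shown sits.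

Among the compounds shown, the methylcarbamoyl end appears on one chain only, so the response of that end to a longer or a shorter chain stays open, and the true size of the chain effect with hydroxycarbamoyl stays undefined. Also open, on these data alone, is whether a carboxylic acid or an amine at the chain end would stay within the scatter of compound 3 and compound 4.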